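Demethylating an Aryl Ether in a Cytotoxicity Screen

A few compounds are considered here, and "the series" means these few. Any claim that something is new, unique, unknown or untested is made for them only; others in the source may bear on it.

In an ADME assay on L6 cells (Rattus norvegicus) for cytotoxicity (on this read-out higher numbers stand for weaker inhibition and lower numbers for stronger inhibition), the measured compounds stand as follows:
compound 1, `COc1cc(C2=NCCN2)ccc1-c1cc2ccc(C3=NCCN3)cc2o1`: 4400 nM
compound 2, `COc1ccc(C2=NCCN2)cc1-c1cc2ccc(C3=NCCN3)cc2o1`: 11100 nM
compound 3, `Oc1cc(C2=NCCN2)ccc1-c1cc2ccc(C3=NCCN3)cc2o1`: > 193000 nM, which is a limit of the assay and not a number

Compound 1 and compound 2 are built from the same atoms joined differently; the difference between the two cores is not broken down here. In this assay compound 2 gives the higher of the two numbers, and its gap to compound 1 lies beyond the usual scatter. Compound 3 sits at a limit, (the limit of > 193000 nM in this assay, at which 1 of the 3 values shown sits). The change that leads from compound 1 to compound 3 is hydrogen in place of methyl on an oxygen on an aromatic ring, and the step it made is an at least 43-fold higher number from compound 1 to compound 3 (1.64 log units; beyond the scatter).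

Compound 4, `Oc1ccc(C2=NCCN2)cc1-c1cc2ccc(C3=NCCN3)cc2o1`, has not yet been measured in this assay. For the measured compounds named here, it differs from compound 2 by hydrogen in place of methyl on an oxygen on an aromatic ring, the same change as the one from compound 1 to compound 3, at a place described in the same words. The step from compound 2 to compound 4 is therefore expected to be a 23-fold higher number from compound 2 to compound 4 (1.35 log units; beyond the scatter), an expectation resting on the step of an at least 43-fold higher number from compound 1 to compound 3 (1.64 log units; beyond the scatter) that this change already made. Compound 4 is estimated at 250000 nM, with a range from 60000 nM to 1000000 nM. Because compound 2 already starts at 11100 nM, the number expected for compound 4 is a high one on this read-out.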

Compound 4, half-maximal inhibitory concentration: > 189000 nM
Compound 4: no number, only a limit; the forecaster's own chance of this, stated with the estimate: 65%; the middle value is on the limit's open side.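

In this assay compound 4 gives > 189000 nM, which is a limit of the assay and not a number. Hydrogen in place of methyl on an oxygen on an aromatic ring, the change from methoxy to hydroxy, gave an at least 17-fold higher number from compound 2 to compound 4 (1.23 log units; beyond the scatter), so on both cores shown it moved the read-out in the same direction, towards weaker inhibition, and by a large step each time. What this does not show is whether the change is worth the same amount on the two cores, since each hydroxy compound is held only by a limit and neither step has a closed size: the same change on two cores in this assay, an at least 43-fold higher number (1.64 log units; beyond the scatter) from compound 1 to compound 3 and an at least 17-fold higher number (1.23 log units; beyond the scatter) from compound 2 to compound 4; the limit leaves it open whether they differ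

The compounds shown hold only methoxy and hydroxy at this place, on two cores, and they leave open how the read-out would respond to an ethoxy group, a longer chain or an amine there. They also leave open how far beyond its limit each of the two hydroxy compounds lies, and whether the same change would give a step of this kind on any core other than these two.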